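A furan swap on compound 2

The source may hold more compounds than are shown below. What is called first, only, known or untested is meant among the compounds shown, and "the series" means these compounds.

So far, a functional assay on HCT-116 cells (Homo sapiens), read by MTT assay, with a stated time of 72 h (on this read-out higher numbers stand for weaker inhibition and lower numbers for stronger inhibition), has numbers for two compounds. Compound 1 (`CSc1ncnc2c1c(-c1ccoc1)cn2[C@@H]1O[C@H](CO)[C@@H](O)[C@H]1O`) stands at 40 nM and compound 2 (`CNc1ncnc2c1c(-c1ccco1)cn2[C@@H]1O[C@H](CO)[C@@H](O)[C@H]1O`) at 230 nM as the higher of the two, a gap beyond the scatter. Compound 3 (`CNc1ncnc2c1c(-c1ccoc1)cn2[C@@H]1O[C@H](CO)[C@@H](O)[C@H]1O`) is compound 2 with furan-3-yl in place of furan-2-yl on an aromatic carbon of the shared core. For the measured compounds named here, compound 1 and compound 2 differ in more than one place, and no measured step isolates this change. Compound 3 does share the furan-3-yl of compound 1 at 40 nM and that alone suggests a modest expected shift toward lower numbers in this assay that may stay within the scatter. The estimate amounts to a 1.8-fold lower number from compound 2 to compound 3 (0.25 log units; within the scatter) at its middle. Compound 3 is expected at 130 nM (estimated range 40 nM to 400 nM).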

Compound 3, half-maximal inhibitory concentration: > 20000 nM
Compound 3: only a limit was reported; the forecaster's own chance of this, stated with the estimate: 3%; middle value at least 150-fold (2.18 log units) away from the limit.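

In this assay, the furan on this aromatic carbon matters by its point of attachment alone: with the same atoms joined differently, furan-3-yl in place of furan-2-yl gives an at least 86-fold higher number from compound 2 to compound 3 (1.93 log units; beyond the scatter) with methylamino held fixed. Furan-3-yl does not settle the outcome by itself, as methylamino in place of methylsulfanyl, with that furan held fixed, gives an at least 500-fold higher number from compound 1 to compound 3 (2.69 log units; beyond the scatter) in the same assay. Both steps rest on compound 3, whose entry is a limit and not a number: the limit of > 20000 nM in this assay, at which 1 of the 3 values shown sits.

The compounds shown leave open how a methylsulfanyl compound with furan-2-yl would read, so the two changes cannot yet be set against each other. They also leave open how this assay would respond to a thiophene or a phenyl at this place, or to a dimethylamino group in place of methylamino.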